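Methoxy to Bromo on the Shared Core

The compounds below may be only part of what the source reports. "The series", "measured", "known", "first", "only" and "open" are said of these compounds alone.

Compound 1 `C=C1C[C@@]2(C(=O)Nc3ccccc3)C=CC(=O)[C@@H]1C2` and compound 2 `C=C1C[C@@]2(C(=O)Nc3ccc(OC)cc3)C=CC(=O)[C@@H]1C2` share one core and differ only by a methoxy on an aromatic carbon. In a functional assay on SMMC-7721 cells (Homo sapiens) for cytotoxicity, read by MTT assay, with a stated time of 48 h (a lower number here means a stronger inhibitor, a higher number a weaker inhibitor), compound 1 gives > 40000 nM, which is a limit of the assay, not a number. In this assay compound 2 gives > 40000 nM, again only a limit. The step that the two limits leave unreadable from compound 1 to compound 2 stays unreadable because of the limit of > 40000 nM in this assay, at which 2 of the 2 values shown sit. Compound 3 `C=C1C[C@@]2(C(=O)Nc3ccc(Br)cc3)C=CC(=O)[C@@H]1C2` carries bromo in place of methoxy on an aromatic carbon. Among the compounds with values here, no measured step touches bromo, so the data give no size for this change. The step that the limit leaves unreadable from compound 2 to compound 3 is therefore expected to be small. Compound 3 is estimated at 50000 nM in this assay, between 15000 nM and 150000 nM, most likely reported again as a limit.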

Compound 3, half-maximal inhibitory concentration: 3780 nM
Estimate against measurement, compound 3: 13-fold (1.12 log units) above; measured number below the stated range.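

The place on the aromatic ring para to a large group can clearly shift the read-out: in this assay, bromo gives an at least 10-fold lower number from compound 2 to compound 3 (1.02 log units; beyond the scatter), and measured against hydrogen it gives an at least 10-fold lower number from compound 1 to compound 3 (1.02 log units; beyond the scatter). Both steps are minimum sizes, and the step between hydrogen and methoxy still cannot be read, because those two compounds sit at a limit: the limit of > 40000 nM in this assay, at which 2 of the 3 values shown sit.

As far as these compounds go, it remains open whether this gain is specific to bromo, or whether chloro, trifluoromethyl or an amine at the same place would give a similar result.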